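A few compounds are considered here, and "the series" means these few. Any claim that something is new, unique, unknown or untested is made for them only; others in the source may bear on it.

Compound 1 `COc1ccc([C@@H]2C/C(=N/OCc3cn(-c4ccc(Cl)cc4C)nn3)c3cc(CC=C(C)C)c(OC)cc3O2)cc1` gives 37% in a functional assay on MCF7 cells (Homo sapiens) for inhibition, read by sulforhodamine B assay, with a stated time of 48 h, tested at 50 uM; on this read-out lower numbers stand for less inhibition of growth and higher numbers for more inhibition of growth at the one concentration tested.
Compound 2 `COc1ccc([C@@H]2CC(=O)c3cc(CC=C(C)C)c(OC)cc3O2)cc1` gives 65%.
Compound 3 `COc1ccc([C@@H]2C/C(=N/O)c3cc(CC=C(C)C)c(OC)cc3O2)cc1` gives 63%.

Among these three numbers compound 1 stands lowest. Its nearest neighbour is compound 3, whose value lies higher by a gap beyond the usual scatter, and the furthest is compound 2, higher by a gap that is also beyond the scatter. Compound 4 `COc1ccc([C@@H]2C/C(=N/OCc3cn(-c4ccc(NC(C)=O)cc4)nn3)c3cc(CC=C(C)C)c(OC)cc3O2)cc1` has not yet been measured. It differs from compound 1 in one place: 4-acetamidophenyl in place of 4-chloro-2-methylphenyl on an aromatic nitrogen. Going by the values given here, no pair of measured compounds differs in exactly this way, so there is no measured step to lean on; compounds 2 and 3 carry no aryl group at all at that position, and their values only show that the whole group present in compound 1 goes with a lower number. For compound 4 a step of small size in this assay is expected, in either direction but not beyond the scatter, so that the estimate for compound 4 is 40%, in the range 22% to 58%, which means an expected step of a number 3 percentage points higher from compound 1 to compound 4 (within the scatter).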

Compound 4, percent growth inhibition at one concentration: 0%
The estimate for compound 4 lay 40 percentage points above the measured number; the whole stated range lies above it.
By their numbers in this assay, from the lowest: compound 4; then compound 1; then compounds 3 and 2 (each within the scatter of the next).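

In this assay, the group on the aromatic nitrogen proves far from neutral: 4-acetamidophenyl in place of 4-chloro-2-methylphenyl gives a number 37 percentage points lower from compound 1 to compound 4 (beyond the scatter). Both groups contain the same kind of six-membered aromatic ring, so the large step goes with what that ring carries, and the growth inhibition seen with compound 1 does not survive this change at the one concentration tested. Nothing measured here explains the loss.

This single swap removes the chlorine and the methyl and brings in the acetamido group all at once, so the compounds shown cannot tell which of these differences matters. An unsubstituted phenyl or an aminophenyl group at this position would help to separate these possibilities, but neither is among the compounds shown.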